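Aryl groups on the shared core: compound 3 to compound 4

The compounds below may be only part of what the source reports. "The series", "measured", "known", "first", "only" and "open" are said of these compounds alone.

Compound 1 `CCCCCCCCc1ccc(OCC(=O)Cn2cnnn2)cc1`: 22%
Compound 2 `CCCCCCCCc1ccc(OCC(=O)Cn2nnnc2-c2ccccc2Cl)cc1`: 42%
Compound 3 `CCCCCCCCc1ccc(OCC(=O)Cn2nnnc2-c2ccccn2)cc1`: < 5% (a limit, not a number)

All three compounds were read in an ADME assay on S9 fraction from liver (Rattus norvegicus) for metabolic stability, read by LC-MS, using NADPH, with a stated time of 30 min; a higher number here means that more of the compound is left, a lower number that less of the compound is left. Compound 3 stands at < 5%, which is a limit of the assay and not a number.

Compound 4 `CCCCCCCCc1ccc(OCC(=O)Cn2nnnc2-c2cccc(C(=O)O)c2)cc1` carries the change 3-carboxyphenyl in place of pyridin-2-yl on an aromatic carbon. For the measured compounds named here, three measured steps bear on it. The modest step of a number 20 percentage points higher from compound 1 to compound 2 (beyond the scatter) came with 2-chlorophenyl in place of hydrogen. The step of a number at least 17 percentage points lower from compound 1 to compound 3 (beyond the scatter) came with pyridin-2-yl in place of hydrogen. The large step of a number at least 37 percentage points lower from compound 2 to compound 3 (beyond the scatter) came with pyridin-2-yl in place of 2-chlorophenyl.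

Going by the values given here, compound 2 is the only measured compound with a carbon-only aromatic ring at this place, and no measured compound carries 3-carboxyphenyl, so the guide is thin. A rise beyond the scatter is expected in this assay, and the estimated step is a number at least 25 percentage points higher from compound 3 to compound 4 (beyond the scatter). For compound 4 the expected value is 30%, with an estimated range of 8% to 60%.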

Compound 4, percent of the compound remaining: < 5%
Compound 4: only a limit was reported (the forecaster's own chance of this, stated with the estimate: 15%); middle value at least 25 percentage points away from the limit.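

In this assay compound 4 gives < 5% as a limit and not a number. A carbon-only aromatic ring at this place therefore does not by itself bring the higher read-out of compound 2: 3-carboxyphenyl gives a number at least 37 percentage points lower from compound 2 to compound 4 (beyond the scatter) and, set against hydrogen, a number at least 17 percentage points lower from compound 1 to compound 4 (beyond the scatter) as well, so among the groups shown only 2-chlorophenyl stands above hydrogen. The step between the pyridin-2-yl and 3-carboxyphenyl compounds cannot be read, and the two cannot be ordered: the limit of < 5% in this assay, at which 2 of the 4 values shown sit.

On these data alone, whether the low read-out of compound 4 belongs to the carboxylic acid itself or to its place on the ring stays open. Also open, as far as these compounds go, is how an unsubstituted phenyl or a methyl ester in place of the acid would read.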